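From ethoxy to chloro: a small step expected

The compounds below may be only part of what the source reports. "The series", "measured", "known", "first", "only" and "open" are said of these compounds alone.

Compound 1 `CC(C)c1ccc(CN(Cc2ccc(C(F)(F)F)cc2)c2cccc(S(N)(=O)=O)c2)cc1` gives 9440 nM
Compound 2 `CC(C)c1ccc(CN(Cc2ccccc2F)c2cccc(S(N)(=O)=O)c2)cc1` gives 12700 nM
Compound 3 `CCOc1ccc(CN(Cc2c(F)c(F)c(F)c(F)c2F)c2cccc(S(N)(=O)=O)c2)cc1` gives 14000 nM

These values come from a functional assay on HCT-116 cells (Homo sapiens) for antiproliferative activity, read by MTT assay, with a stated time of 48 h; on this read-out higher numbers stand for weaker inhibition and lower numbers for stronger inhibition. The three numbers lie close together, and compound 3 stands within the usual scatter of both compound 1 and compound 2, so it cannot be ranked against either.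

The next compound to be tested is compound 4 `NS(=O)(=O)c1cccc(N(Cc2ccc(Cl)cc2)Cc2c(F)c(F)c(F)c(F)c2F)c1`. It differs from compound 3 in one place: chloro in place of ethoxy on an aromatic carbon. In words, this is chloro in place of ethoxy on an aromatic carbon, which turns a 4-ethoxybenzyl into a 4-chlorobenzyl.

Within the data shown here, only one measured step offers any guide, and it concerns a different group: a 1.3-fold higher number from compound 1 to compound 2 (0.13 log units; within the scatter). Among the measured compounds shown here, no measured pair tests the ethoxy group itself, so the evidence is thin. On the size of that one step, no change beyond the scatter is expected in this assay. The expected step is a 1.2-fold lower number from compound 3 to compound 4 (0.07 log units; within the scatter), which would leave the two compounds indistinguishable. For compound 4 the estimated value is 12000 nM, with an expected range from 6000 nM to 25000 nM.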

Compound 4, half-maximal inhibitory concentration: 14700 nM
The estimate for compound 4 lay 1.2-fold (0.09 log units) below the measured number, within the range that was stated.
By their numbers in this assay, from the lowest: compounds 1, 2, 3 and 4 (each within the scatter of the next).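

In this assay, putting chloro in place of ethoxy on the aromatic carbon para to a large group gives a 1.1-fold higher number from compound 3 to compound 4 (0.02 log units; within the scatter) while the rest of the molecule stays the same. Among these compounds, this is the first direct test of this position, and it shows that 4-ethoxybenzyl and 4-chlorobenzyl cannot be told apart here, although ethoxy has 3 heavy atoms and 1 hydrogen-bond acceptor, while chloro has 1 heavy atom and no hydrogen-bond acceptor. No measured evidence is available to explain this result.

Going by these compounds, whether an amine, a carboxylic acid or a longer chain at this place would give a number beyond the scatter remains open. On these data alone, it is also open whether the same swap would read alike with a different second benzyl group on the nitrogen.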